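The source may report more compounds than this note shows. Statements on the series, on what has been measured and on what is new or still open speak of the compounds shown alone.

Working notes on the series. Compound 1 `COc1cc(OC)c(-c2coc3cc(OCC(=O)c4cccc(C(F)(F)F)c4)ccc3c2=O)cc1OC`, compound 2 `COc1cc(OC)c(-c2coc3cc(OCc4cccc(Br)c4)ccc3c2=O)cc1OC` and compound 3 `COc1cc(OC)c(-c2coc3cc(OCc4ccc(C(F)(F)F)cc4)ccc3c2=O)cc1OC` share one core and differ only in the group on a saturated chain carbon bound to an oxygen on an aromatic ring. In a functional assay on HepG2 cells (Homo sapiens) for antiproliferative activity, read by MTT assay, with a stated time of 24 h (on this read-out lower numbers stand for stronger inhibition and higher numbers for weaker inhibition), compound 1 gives > 10000 nM, which is a limit of the assay and not a number. Compound 2 gives 870 nM in this assay. Among the measured compounds shown here, the one measured step is an at least 11-fold lower number from compound 1 to compound 2 (1.06 log units; beyond the scatter); its size is bounded only because compound 1 sits at the limit of > 10000 nM in this assay, at which 1 of the 2 values shown sits, so the true step may be larger.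

Compound 3 differs from compound 1 as follows: 4-(trifluoromethyl)phenyl in place of (3-(trifluoromethyl)phenyl)carbonyl on a saturated chain carbon bound to an oxygen on an aromatic ring. As with compound 2, the carbonyl-bearing group leaves and an aryl is attached directly to that chain carbon, though here the trifluoromethyl is retained and moved from the 3-position to the 4-position. For the measured compounds named here, the step of an at least 11-fold lower number from compound 1 to compound 2 (1.06 log units; beyond the scatter) is the only comparison that bears on this change, and a step of similar direction and size is expected in this assay. The expected step is an at least 6.6-fold lower number from compound 1 to compound 3 (0.82 log units; beyond the scatter). Compound 3 is therefore estimated at 1500 nM, with a range from 400 nM to 7000 nM.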

Compound 3, half-maximal inhibitory concentration: 890 nM
Compound 3: middle estimate off by 1.7-fold (0.23 log units), on the high side; the measured number falls inside the stated range.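

In this assay compound 3 gives a second step out of compound 1, an at least 11-fold lower number from compound 1 to compound 3 (1.05 log units; beyond the scatter), and its true size is again open: the limit of > 10000 nM in this assay, at which 1 of the 3 values shown sits.

The large step therefore no longer rests on the 3-bromophenyl group alone: compounds 2 and 3 both carry an aryl group directly on the saturated chain carbon, and the presence of a trifluoromethyl group does not by itself go with the weak result of compound 1. The two aryl groups are not told apart at this place, with a 1.0-fold higher number from compound 2 to compound 3 (0.01 log units; within the scatter), so 4-(trifluoromethyl)phenyl and 3-bromophenyl read as equal in this assay.

The step from compound 1 to compound 3 removes the carbonyl and moves the trifluoromethyl group in a single change, so the compounds shown do not say how much of the step belongs to each; 3-(trifluoromethyl)phenyl on the same chain carbon would separate the two. Also open is how this place would respond to an aryl group carrying an amine or a carboxylic acid, since both aryl groups shown carry only a halogen or a trifluoromethyl group.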